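Dropping the methoxy from compound 1: what to expect

The source may report more compounds than this note shows. Statements on the series, on what has been measured and on what is new or still open speak of the compounds shown alone.

Measured in an assay on isolated protein for inhibition of thiosulfate sulfurtransferase (Homo sapiens), with a stated time of 60 min, in the absence of a further agent; a lower number here means a stronger inhibitor, a higher number a weaker inhibitor:
compound 1 `COc1ccc(Br)cc1C(=O)Nc1ccc(Sc2nc3ccccc3s2)cc1`, > 100000 nM.
compound 2 `O=C(Nc1ccccc1)c1cccc(Br)c1O`, > 100000 nM.
compound 3 `COc1c(Br)cc(Br)cc1C(=O)Nc1ccc(Sc2nc3ccccc3s2)cc1`, > 100000 nM.

The value of compound 1 is a limit of the assay and not a number. The value of compound 2 is likewise a limit. The value of compound 3 is a limit as well. So compound 1 stands at the limit in this assay, and the two other values shown stand there too. For the measured compounds named here, the one change that can be followed between measured compounds, bromo in place of hydrogen on an aromatic carbon, gives a step that the two limits leave unreadable from compound 1 to compound 3, unreadable because both ends sit at the limit of > 100000 nM in this assay, at which 3 of the 3 values shown sit.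

Compound 4 `O=C(Nc1ccc(Sc2nc3ccccc3s2)cc1)c1cccc(Br)c1` is the next compound, not yet measured in this assay. It differs from compound 1 by hydrogen in place of methoxy on an aromatic carbon. No measured step touches this change, and the only step from compound 1 is unreadable, so nothing in the shown data points to a gain or a loss. With compound 1 at the limit and no readable step, compound 4 is expected to remain near the limit as well: the estimate for compound 4 is 150000 nM, between 40000 nM and 600000 nM, which means an expected step that the limit leaves unreadable from compound 1 to compound 4.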

Compound 4, half-maximal inhibitory concentration: > 100000 nM
Compound 4: a limit, no number; the forecaster's own chance of this, stated with the estimate: 85%; the middle value is on the limit's open side.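

Compound 4 gives > 100000 nM in this assay, which is a limit and not a number, so no step can be read between compound 1 and compound 4, because both sit at the same limit: the limit of > 100000 nM in this assay, at which 4 of the 4 values shown sit.

The compounds shown leave open whether the methoxy or bromo groups have any effect on inhibition, and which change, if any, would give a measurable value.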